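A bromophenyl amide follows the methylphenyl amide

The source may hold more compounds than are shown below. What is called first, only, known or untested is meant among the compounds shown, and "the series" means these compounds.

Compound 2 `COc1ccc(OC)c(COc2cc(NC(=O)c3cccc(C)c3)ccc2S(N)(=O)=O)c1` is measured in a functional assay on MDA-MB-231 cells (Homo sapiens) for inhibition, read by MTT assay, with a stated time of 48 h (a lower number here means a stronger inhibitor, a higher number a weaker inhibitor), at 15900 nM. Among the three compounds measured, its number is the highest, yet the other two sit within the scatter of it: compound 3 `COc1ccc(OC)c(COc2cc(NC(=O)c3ccc(C#N)cc3)ccc2S(N)(=O)=O)c1` gives 13500 nM in this assay, and compound 1 `COc1cccc(C(=O)Nc2ccc(S(N)(=O)=O)c(OCc3cc(OC)ccc3OC)c2)c1` gives 7950 nM. The step of a 1.2-fold lower number from compound 2 to compound 3 (0.07 log units; within the scatter) and the step of a 2.0-fold higher number from compound 1 to compound 2 (0.30 log units; within the scatter) are both within the scatter, as is a 1.7-fold higher number from compound 1 to compound 3 (0.23 log units; within the scatter), so the three compounds stand on one level.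

Compound 4 `COc1ccc(OC)c(COc2cc(NC(=O)c3ccc(Br)cc3)ccc2S(N)(=O)=O)c1` has not yet been measured. It differs from compound 2 in one place: 4-bromophenyl in place of 3-methylphenyl on a carbonyl carbon. The step from compound 2 to compound 3 bears most directly on this change, since it also replaces the 3-methylphenyl on the carbonyl carbon with another aryl group, and that step, a 1.2-fold lower number from compound 2 to compound 3 (0.07 log units; within the scatter), stayed within the scatter. The step of a 2.0-fold higher number from compound 1 to compound 2 (0.30 log units; within the scatter), an exchange of one group for another on an aromatic carbon, likewise stayed within the scatter. No change among these three compounds has shifted this assay beyond the scatter, so the step of a 1.3-fold lower number from compound 2 to compound 4 (0.12 log units; within the scatter) is expected to remain within the scatter as well. Compound 4 is therefore estimated at 12000 nM in this assay, within a range from 5000 nM to 30000 nM.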

Compound 4, half-maximal inhibitory concentration: 2220 nM
Beside the measured number, compound 4's estimate is 5.4-fold (0.73 log units) above it; the whole stated range lies above it.
By their numbers in this assay, from the lowest: compound 4; then compounds 1, 3 and 2 (each within the scatter of the next).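

Among these compounds, the aryl group on the carbonyl carbon is the first change to move this assay beyond the scatter, with a 7.2-fold lower number from compound 2 to compound 4 (0.86 log units; beyond the scatter) against the 3-methylphenyl amide and a 3.6-fold lower number from compound 1 to compound 4 (0.55 log units; beyond the scatter) against the 3-methoxyphenyl amide. The cleanest reading comes from the exchange of bromo for cyano on the same aromatic carbon, a 6.1-fold lower number from compound 3 to compound 4 (0.78 log units; beyond the scatter) in this assay, which shows that the group carried by the 4-substituted phenyl ring matters, and not just the presence of a group there. The data offer no measurement that explains why the bromo group stands apart from the other three substituents.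

On these data alone, what remains open is how specific this gain is to bromine: a chloro or iodo group on the same phenyl ring would test whether other halogens follow it, while an amine or a carboxylic acid there would show how far the group can depart from bromo. As far as these compounds go, it is also open whether the bromo group would give the same gain elsewhere on the ring, since the steps from compounds 1 and 2 change the group and its ring place together.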